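Notes on compound 3, the mirror image of compound 1

The source may report more compounds than this note shows. Statements on the series, on what has been measured and on what is new or still open speak of the compounds shown alone.

Compound 1 `COc1cc([C@@H]2C[C@@]2(CO)C(=O)Nc2ccccc2)cc(OC)c1OC`: 36700 nM
Compound 2 `COc1cc([C@@H]2C[C@@]2(CO)C(=O)NCc2ccc(C)cc2)cc(OC)c1OC`: 58700 nM
Compound 3 `COc1cc([C@H]2C[C@]2(CO)C(=O)Nc2ccccc2)cc(OC)c1OC`: not yet measured

All values come from a functional assay on QGY cells (Homo sapiens) for cytotoxicity, read by MTT assay, with a stated time of 48 h; on this read-out higher numbers stand for weaker inhibition and lower numbers for stronger inhibition. Going by the values given here, no measured value stands clearly apart from that of compound 1: the only step, a 1.6-fold higher number from compound 1 to compound 2 (0.20 log units; within the scatter), concerns the amide substituent. Compound 3 differs from compound 1 as follows: the two compounds have the same atoms and bonds and differ only in configuration as drawn: 2 of 2 stereo elements differ (all stereocentres are inverted: mirror images); a stereocentre at a saturated ring carbon is drawn S in compound 1 and R in compound 3; a stereocentre at a saturated ring carbon is drawn R in compound 1 and S in compound 3. Among the compounds with values here, no measured step tests configuration, so that step bears only indirectly, and no shift beyond the scatter is assumed. The expected step is a 1.1-fold higher number from compound 1 to compound 3 (0.04 log units; within the scatter). Compound 3 is estimated at 40000 nM, with an expected range of 15000 nM to 100000 nM.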

Compound 3, half-maximal inhibitory concentration: > 100000 nM
Compound 3: a limit, no number (the forecaster's own chance of this, stated with the estimate: 15%); middle value at least 2.5-fold (0.39 log units) away from the limit.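

In this assay, going by these compounds alone, inverting both ring stereocentres gives an at least 2.7-fold higher number from compound 1 to compound 3 (0.43 log units; beyond the scatter), the first step beyond the scatter, so configuration counts at this position of the series. Compound 3 gives > 100000 nM, which is a limit and not a number. The shift can be assigned to configuration alone: the fact that compounds 1 and 3 differ only in the configuration as drawn

Open, as far as these compounds go, is the true size of the step, and whether inverting a single stereocentre is enough. Also open, from the compounds shown here alone, is whether the same order of the mirror images holds with a carboxylic acid in place of the hydroxymethyl group.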